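A few compounds are considered here, and "the series" means these few. Any claim that something is new, unique, unknown or untested is made for them only; others in the source may bear on it.

Compound 2 `O=C(CCSc1nc2cc(Cl)ccc2o1)N1CCC1` gives 3.7 mL/min/g in an ADME assay on microsomes from liver (Homo sapiens) for metabolic stability, read by LC-MS, using NADPH, with a stated time of 45 min, tested at 0.5 uM (on this read-out lower numbers stand for slow clearance and higher numbers for fast clearance), the second highest of the three numbers. Compound 1 `O=C(CCCSc1nc2cc(Cl)ccc2o1)N1CCCC1` gives 3.4 mL/min/g in this assay, within the scatter of compound 2, while compound 3 `O=C(CCSc1nc2cc(Cl)ccc2o1)N1CCCCC1` gives 10.7 mL/min/g. Going by the values given here, the only measured step is a 2.9-fold higher number from compound 2 to compound 3 (0.46 log units; beyond the scatter). Compound 4 `Clc1ccc2oc(SCCCN3CCCC3)nc2c1` differs from compound 2 by (pyrrolidin-1-yl)methyl in place of (azetidin-1-yl)carbonyl on a saturated chain carbon, two bonds along the chain from a sulfur. Among the compounds with values here, that one measured step enlarges the ring on the carbonyl carbon and keeps the carbonyl; no measured step removes the carbonyl, so it bears on the new change only in part. The expected step in this assay is therefore a 1.4-fold higher number from compound 2 to compound 4 (0.13 log units; within the scatter), a small rise that may well stay within the scatter. Compound 4 is estimated at 5 mL/min/g, with a range of 2.5 mL/min/g to 10 mL/min/g.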

Compound 4, intrinsic clearance in a liver preparation (reported as CLH), per the amount of preparation that the assay uses: 1.9 mL/min/g
For compound 4 the middle estimate is 2.6-fold (0.42 log units) above the measured one, outside the stated range (below it).
By their numbers in this assay, from the lowest: compounds 4, 1 and 2 (each within the scatter of the next); then compound 3.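

Replacing the carbonyl-bearing group leaves this assay within the scatter, with a 1.9-fold lower number from compound 2 to compound 4 (0.29 log units; within the scatter) as the step that also changes the ring. With the pyrrolidin-1-yl ring kept, a 1.8-fold lower number from compound 1 to compound 4 (0.25 log units; within the scatter) likewise stays within the scatter, so at this position the carbonyl is not required for a low number in these two comparisons. No measurement at hand accounts for either step.

On these data alone, whether the same holds for a piperidin-1-yl group without the carbonyl remains open. So does the outcome with a morpholine or a dimethylamino group on the same chain.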